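The compounds below may be only part of what the source reports. "The series", "measured", "known", "first", "only" and "open" are said of these compounds alone.

Measured so far:
compound 1 `COc1cc(OCc2cccc(COc3ccccc3)c2)c2cc(-c3cn4nc(OC)sc4n3)oc2c1` — 86%
compound 2 `COc1cc(OCc2ccccc2OCc2ccccc2)c2cc(-c3cn4nc(OC)sc4n3)oc2c1` — 94%

Both compounds were tested in an ADME assay on microsomes from liver (Homo sapiens) for metabolic stability, with a stated time of 10 min; a higher number here means that more of the compound is left, a lower number that less of the compound is left. Compound 1 gives 86% there, and compound 2 gives 94%. Compound 1 holds the lower of the two numbers, yet the gap to compound 2 falls within the scatter of this assay, so the two cannot be told apart on these data.

Compound 3 `COc1cc(OCc2cccc(CCc3ccccc3)c2)c2cc(-c3cn4nc(OC)sc4n3)oc2c1` has not been measured. It differs from compound 1 in one place: benzyl in place of phenoxy on a saturated chain carbon bound to an aromatic carbon. Seen one bond further out, phenoxymethyl gives way to phenethyl; an oxygen is traded for a carbon on the link that joins the two outer rings, and one hydrogen-bond acceptor is lost.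

Among the measured compounds shown here, no step between two measured compounds shows what such a change does in this assay, so there is nothing to lean on beyond the two values themselves. With both near the top of the scale and the change small, the step is expected to stay within the scatter, with at most a slight drift downward: a number 4 percentage points lower from compound 1 to compound 3 (within the scatter). Compound 3 is therefore estimated at 82%, expected to lie between 65% and 95%.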

Compound 3, percent of the compound remaining: 99%
Compound 3: the middle estimate sits 17 percentage points below what was measured; the measured number lies above the stated range.
By their numbers in this assay, from the lowest: compounds 1, 2 and 3 (each within the scatter of the next, the first and the last beyond it).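

In this assay, benzyl in place of phenoxy on a saturated chain carbon bound to an aromatic carbon gives a number 13 percentage points higher from compound 1 to compound 3 (beyond the scatter), and this is the only step shown that isolates a single change at this place. It shows that the link joining the two outer rings is not a silent spot for this read-out: trading its oxygen for a carbon, with one hydrogen-bond acceptor fewer and the same number of heavy atoms in the group, moves the number beyond the usual scatter, although the step is modest. Nothing at hand accounts for this shift, so it stands as an observation only.

The compounds shown hold just this one swap at this place, so it stays open whether the oxygen itself matters or the group as a whole, and a link carrying an amine nitrogen or a longer chain between the two outer rings would help to separate these. Going by these compounds, it also stays open whether the same swap would give a similar step on compound 2, and whether the step would persist over a longer incubation.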